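This account rests on a few compounds, and the source may have more. Where it says the series, first, only, none or still open, it means among the compounds named here.

Compound 1 `COc1ccc(-c2cc(/C=C/C(=O)c3ccc(N)cc3)[nH]n2)cc1` and compound 2 `COc1cc(-c2cc(/C=C/C(=O)c3ccc(N)cc3)[nH]n2)cc(OC)c1OC` share one core and differ in only one place. In a functional assay on OVCAR-4 cells (Homo sapiens) for inhibition, read by sulforhodamine B assay, with a stated time of 48 h (a lower number here means a stronger inhibitor of growth, a higher number a weaker inhibitor of growth), compound 1 gives 8010 nM, while compound 2 gives 5440 nM; that is the lower of the two numbers, yet the gap to compound 1 lies within the usual scatter, so neither can be ranked above the other. Compound 3 `COc1cc(-c2cc(/C=C/C(=O)c3ccc(Cl)c(Cl)c3)[nH]n2)cc(OC)c1OC` differs from compound 2 by 3,4-dichlorophenyl in place of 4-aminophenyl on a carbonyl carbon. Among the compounds with values here, no measured pair shows this change, so nothing here points to a direction. In this assay the step from compound 2 to compound 3 is expected to stay within the scatter, about a 1.1-fold higher number from compound 2 to compound 3 (0.04 log units; within the scatter). Compound 3 is therefore estimated at 6000 nM, with a range from 2000 nM to 18000 nM.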

Compound 3, concentration for total growth inhibition: 50900 nM
Beside the measured number, compound 3's estimate is 8.5-fold (0.93 log units) below it; the measured number lies above the stated range.
By their numbers in this assay, from the lowest: compounds 2 and 1 (each within the scatter of the next); then compound 3.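

The group on the carbonyl carbon clearly matters in this assay: 3,4-dichlorophenyl in place of 4-aminophenyl gives a 9.4-fold higher number from compound 2 to compound 3 (0.97 log units; beyond the scatter). Within the data shown here, this is the first step here that lies beyond the scatter, and it makes compound 3 the weaker inhibitor of growth compared with compound 2. Nothing available explains this loss.

Going by these compounds, whether the step follows the loss of the amino group or the arrival of the two chlorines stays open. Plain phenyl or 4-chlorophenyl on that carbonyl carbon could separate the two.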